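Ortho-nitro added to the 4-nitrophenyl analogue

The source may report more compounds than this note shows. Statements on the series, on what has been measured and on what is new or still open speak of the compounds shown alone.

The series shares the enone-benzoate core of compound 1 `C=C(C(=O)c1ccc(OC)cc1)C(OC(=O)c1ccccc1)c1ccccc1F` and varies the aryl group on the saturated chain carbon. In a functional assay on MCF7 cells (Homo sapiens) for inhibition, read by XTT assay, with a stated time of 48 h (on this read-out lower numbers stand for stronger inhibition and higher numbers for weaker inhibition), compound 1 gives 34200 nM. Compound 2 `C=C(C(=O)c1ccc(OC)cc1)C(OC(=O)c1ccccc1)c1ccc([N+](=O)[O-])cc1` gives 56100 nM in this assay, and compound 3 `C=C(C(=O)c1ccc(OC)cc1)C(OC(=O)c1ccccc1)c1ccccc1Cl` gives 36000 nM. Compound 2 sits at the high end of the three numbers, but the two steps that place it, a 1.6-fold higher number from compound 1 to compound 2 (0.21 log units; within the scatter) and a 1.6-fold lower number from compound 2 to compound 3 (0.19 log units; within the scatter), are both within the scatter, as is a 1.1-fold higher number from compound 1 to compound 3 (0.02 log units; within the scatter).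

Compound 4 `C=C(C(=O)c1ccc(OC)cc1)C(OC(=O)c1ccccc1)c1ccc([N+](=O)[O-])cc1[N+](=O)[O-]` is not yet measured. Its change from compound 2 is nitro in place of hydrogen on an aromatic carbon, in words: nitro in place of hydrogen on an aromatic carbon, ortho to a large group and meta to a nitro group. The measured steps that bear on it are those changing the aryl substituent pattern, a 1.6-fold higher number from compound 1 to compound 2 (0.21 log units; within the scatter) and a 1.6-fold lower number from compound 2 to compound 3 (0.19 log units; within the scatter); neither left the scatter, so no step beyond the scatter is expected for this assay. Compound 4 is therefore expected to show a 1.0-fold lower number from compound 2 to compound 4 (0.00 log units; within the scatter). The estimate for compound 4 in this assay is 56000 nM, with a range from 25000 nM to 125000 nM.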

Compound 4, half-maximal inhibitory concentration: > 100000 nM
Compound 4: a limit, no number (the forecaster's own chance of this, stated with the estimate: 15%); at least 1.7-fold (0.25 log units) between middle value and limit.
By their numbers in this assay, from the lowest: compounds 1, 3 and 2 (each within the scatter of the next). At a limit, above all of these: compound 4.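

In this assay compound 4 gives > 100000 nM, which is a limit of the assay and not a number. This is the first aryl ring in the series shown with two substituents, the added nitro standing ortho to a large group and meta to a nitro group, and the result reads as an at least 1.7-fold higher number from compound 2 to compound 4 (0.25 log units; that floor lies within the scatter), so the real size of the change stays unknown and no loss of inhibition is established. Compound 4 alone of the series stands at the limit: the limit of > 100000 nM in this assay, at which 1 of the 4 values shown sits.

On these data alone, it remains open whether an amine or a carboxylic acid at this position would give a measurable number in this assay. Also open, as far as these compounds go, is how a nitro group at this position behaves when the aryl ring carries no other nitro group.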